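A Nitro Group Joins the Phenyl Ring of Compound 3

This account rests on a few compounds, and the source may have more. Where it says the series, first, only, none or still open, it means among the compounds named here.

Three compounds share one core and differ only in the aromatic ring carried on it. Compound 1 `O=[N+]([O-])c1cc2c(OCCC3CCCCN3)c(-c3ccccc3Cl)c(O)nc2cc1Cl` gives 360 nM in a functional assay on cells (Pituitary gland cell) for antagonist activity at Gonadotropin-releasing hormone receptor (Rattus norvegicus); a lower number here means a stronger inhibitor, a higher number a weaker inhibitor. Compound 2 `O=[N+]([O-])c1cc2c(OCCC3CCCCN3)c(-c3cccc(F)c3)c(O)nc2cc1Cl` gives 53 nM in this assay, and compound 3 `O=[N+]([O-])c1cc2c(OCCC3CCCCN3)c(-c3ccccc3)c(O)nc2cc1Cl` gives 410 nM. Compound 3 therefore holds the highest of the three numbers; its gap to compound 1 lies within the scatter (a 1.1-fold higher number from compound 1 to compound 3 (0.06 log units; within the scatter)), while compound 2 sits clearly apart (a 7.7-fold higher number from compound 2 to compound 3 (0.89 log units; beyond the scatter)).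

Compound 4 `O=[N+]([O-])c1cccc(-c2c(O)nc3cc(Cl)c([N+](=O)[O-])cc3c2OCCC2CCCCN2)c1` arises from compound 3 by nitro in place of hydrogen on an aromatic carbon. For the measured compounds named here, the step that bears most directly on this is the one from compound 2 to compound 3, where fluoro gave way to hydrogen on that same ring and the number rose beyond the scatter. The other step, a 6.8-fold lower number from compound 1 to compound 2 (0.83 log units; beyond the scatter), concerns a different substituent on a different carbon and is less telling. A substituent at this carbon has so far gone with a lower number, but nitro is not fluoro, so only a modest drop is expected, a 2.7-fold lower number from compound 3 to compound 4 (0.44 log units; beyond the scatter). Compound 4 is accordingly estimated to give about 150 nM in this assay, within a likely range from 40 nM to 600 nM.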

Compound 4, half-maximal inhibitory concentration: 100 nM
Estimate against measurement, compound 4: 1.5-fold (0.18 log units) above, within the range that was stated.
By their numbers in this assay, from the lowest: compounds 2 and 4 (each within the scatter of the next); then compounds 1 and 3 (each within the scatter of the next).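

In this assay, nitro now joins fluoro as a second substituent on this carbon that goes with a lower number than hydrogen (see a 4.1-fold lower number from compound 3 to compound 4 (0.61 log units; beyond the scatter)), so the earlier gain no longer rests on fluoro alone. Exchanging fluoro for nitro leaves the number within the scatter (a 1.9-fold higher number from compound 2 to compound 4 (0.28 log units; within the scatter)), and the 3-nitrophenyl group also improves on 2-chlorophenyl (a 3.6-fold lower number from compound 1 to compound 4 (0.56 log units; beyond the scatter)). Nothing measured here explains why these two different substituents give such similar results.

Fluoro and nitro are the only substituents shown on this carbon, so an amine, a carboxylic acid or a longer chain there could give a quite different number. From the compounds shown here alone, it also remains open how nitro would behave on another carbon of the phenyl ring.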